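Lengthening the Chain in an Aminodiol Series

The source may report more compounds than this note shows. Statements on the series, on what has been measured and on what is new or still open speak of the compounds shown alone.

compound 1 `NC(CO)(CO)CCCCCCCCCCc1ccccc1` — 0.3 mg/kg
compound 2 `CCCCCCCc1ccc(CCC(N)(CO)CO)cc1` — 0.1 mg/kg

In a functional assay on the whole organism with Rattus norvegicus as the target (a lower number here means that less compound is needed, a higher number that more compound is needed for the effect), compound 2 gives 0.1 mg/kg, the lowest of the two numbers; the nearest is compound 1, which gives 0.3 mg/kg, a gap beyond the scatter. Compound 3 `CCCCCCCCCCCCc1ccc(CCC(N)(CO)CO)cc1` differs from compound 2 by pentyl in place of hydrogen on a saturated chain carbon, seven bonds along the chain from an aromatic carbon. For the measured compounds named here, no step between measured compounds that differ in one place is available, so the size of this change has to be judged from the two numbers alone. A modest rise in the number, slightly beyond the scatter, is expected: a 3.0-fold higher number from compound 2 to compound 3 (0.48 log units; beyond the scatter). Compound 3 is therefore estimated at 0.3 mg/kg, with a range from 0.07 mg/kg to 1.2 mg/kg.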

Compound 3, dose for 50% inhibition: 0.1 mg/kg
Compound 3: the middle estimate sits 3.0-fold (0.48 log units) above what was measured, within the range that was stated.
By their numbers in this assay, from the lowest: compounds 2 and 3 (each within the scatter of the next); then compound 1.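

In this assay, pentyl in place of hydrogen on a saturated chain carbon, seven bonds along the chain from an aromatic carbon, gives no change at the digits printed from compound 2 to compound 3 (within the scatter). The earlier compounds shown here offered no step in one place, and this one shows that the added pentyl leaves the number within the scatter at this position. Nothing shown accounts for this result. Open, going by these compounds, is whether a longer chain at this place would also leave the number within the scatter. Also open, on these data alone, is how a carboxylic acid or a cyclohexyl group there would read.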